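A few compounds are considered here, and "the series" means these few. Any claim that something is new, unique, unknown or untested is made for them only; others in the source may bear on it.

Compound 1, with the structure `CCOC(=O)c1cccc(S(N)(=O)=O)c1`, and compound 2, with the structure `CCCOC(=O)c1cccc(S(N)(=O)=O)c1`, share a core and differ in one place: methyl in place of hydrogen on a saturated chain carbon, two bonds along the chain from an oxygen next to a carbonyl group. In a physicochemical assay for lipophilicity (on this read-out higher numbers stand for higher lipophilicity and lower numbers for lower lipophilicity), compound 1 gives 1.11, and compound 2 gives 1.72, so that a number 0.61 log units higher from compound 1 to compound 2 (beyond the scatter). Compound 3, with the structure `CCCOC(=O)c1ccccc1S(N)(=O)=O`, is built on a different core; how its core differs from the core of compound 1 is not broken down here. In this assay compound 3 gives 1.49, a number that is within the scatter of compound 2 and beyond it only against compound 1.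

Compound 4, with the structure `CCCCOC(=O)c1ccccc1S(N)(=O)=O`, has not yet been measured. It differs from compound 3 by methyl in place of hydrogen on a saturated chain carbon, three bonds along the chain from an oxygen next to a carbonyl group. Going by the values given here, this is the same kind of change as the one from compound 1 to compound 2, but the place is not the same: there the new carbon sits two bonds along the chain from an oxygen next to a carbonyl group, here three bonds along. Because a number 0.61 log units higher from compound 1 to compound 2 (beyond the scatter) was seen for the earlier step, a similar rise is expected here, so that a number 0.56 log units higher from compound 3 to compound 4 (beyond the scatter) is the expected step. Compound 4 is therefore expected to give about 2.05 in this assay, most likely between 1.7 and 2.4.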

Compound 4, partition coefficient: 2.01
Compound 4: middle estimate off by 0.04 log units, on the high side, and the stated range covers the measured number.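

In this assay the change carries over from one core to the other in direction and rough size: going from propyl to butyl gives a number 0.52 log units higher from compound 3 to compound 4 (beyond the scatter) and the same kind of change on the other core gave a number 0.61 log units higher from compound 1 to compound 2 (beyond the scatter) as well, both modest. Going by these compounds alone, this does not show that the step is independent of the core: each core supplies only one pair, and the new carbon sits three bonds along the chain from an oxygen next to a carbonyl group on one core but two bonds along on the other, so the effects of core and place cannot be told apart. Nothing available here accounts for the size of either step.

The compounds shown leave open whether the rise would continue with a longer chain such as pentyl, and what a carboxylic acid or an amine at the end of the chain would do to the number. They also leave open whether the step would hold on any third core.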